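The source may hold more compounds than are shown below. What is called first, only, known or untested is meant among the compounds shown, and "the series" means these compounds.

Two esters sharing a common core have been measured. Compound 1 `CCCC(=O)O[C@H]1C(=O)OCC1(C)C` carries a butanoyl ester; in an assay on isolated protein for inhibition of fatty acid synthase (Mus musculus), read by spectrophotometry, using NADPH, with stated times of 30 min and 3 min, in the presence of a further agent that is not named here (on this read-out lower numbers stand for stronger inhibition and higher numbers for weaker inhibition), compound 1 gives 28200 nM. Compound 2 `CC1(C)COC(=O)[C@@H]1OC(=O)c1ccc(Cl)cc1` carries a chlorobenzoyl ester instead; in this assay compound 2 gives 19200 nM. Among the two numbers shown, compound 2 stands at the lower one, but its nearest neighbour, compound 1, lies close enough that the gap between them falls within the usual scatter of such measurements, so no order can be read from these two values.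

Compound 3 `Cc1ccc(C(=O)O[C@H]2C(=O)OCC2(C)C)cc1` has not yet been measured. It differs from compound 2 in one place: methyl in place of chloro on an aromatic carbon, para to a large group. For the measured compounds named here, no measured pair in this set shows what such an exchange does, so the size of the step can only be estimated. A small step is expected for compound 3, in no clear direction and not beyond the scatter, with an estimated value of 24000 nM and a range from 8000 nM to 75000 nM, corresponding to a change of a 1.3-fold higher number from compound 2 to compound 3 (0.10 log units; within the scatter).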

Compound 3, half-maximal inhibitory concentration: 17200 nM
Compound 3: the middle estimate sits 1.4-fold (0.14 log units) above what was measured; the measured number falls inside the stated range.
By their numbers in this assay, from the lowest: compounds 3, 2 and 1 (each within the scatter of the next).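

Methyl in place of chloro on an aromatic carbon, para to a large group, gives a 1.1-fold lower number from compound 2 to compound 3 (0.05 log units; within the scatter) in this assay, and this is the first pair in the set that isolates a single exchange at this place. At this position, the two groups cannot be told apart by this read-out, so a methyl can stand where the chloro stood without any difference that rises above the scatter. The exchange is a narrow test, since each group counts one heavy atom, with no hydrogen-bond donors, no hydrogen-bond acceptors and no net charge, and nothing at hand explains why the two groups read alike.

From the compounds shown here alone, what a carboxylic acid, an amine or a longer chain on that aromatic carbon would do in this assay stays open, and so does whether any group there can move the number beyond the scatter. Also open is what an amide in place of the ester link would do; every compound shown carries that ester.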